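The source may hold more compounds than are shown below. What is called first, only, known or untested is meant among the compounds shown, and "the series" means these compounds.

Compound 3 `Nc1nc(N)c2c(-c3ccccc3)cn([C@@H]3O[C@H](CO)[C@@H](O)[C@H]3O)c2n1` is one of three measured compounds that share the same core and differ in the ring attached to it. In a functional assay on CCRF-CEM cells (Homo sapiens), read by MTT assay, with a stated time of 72 h (a lower number here means a stronger inhibitor, a higher number a weaker inhibitor), compound 3 gives > 20000 nM, which is a limit of the assay rather than a number. Compound 1 `Nc1nc(N)c2c(-c3ccsc3)cn([C@@H]3O[C@H](CO)[C@@H](O)[C@H]3O)c2n1` carries a thiophen-3-yl group in that position, and in this assay compound 1 gives > 20000 nM, again a limit. Compound 2 `Cc1nc(N)c2c(-c3cc4ccccc4o3)cn([C@@H]3O[C@H](CO)[C@@H](O)[C@H]3O)c2n1` carries a benzofuran ring and a methyl group on the core, and in this assay compound 2 gives > 20000 nM, also a limit. For the measured compounds named here, the one step between compounds that differ in a single place, a step that the two limits leave unreadable from compound 1 to compound 3, cannot be read because of the limit of > 20000 nM in this assay, at which 3 of the 3 values shown sit.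

Compound 4 `Cc1nc(N)c2c(-c3ccccc3)cn([C@@H]3O[C@H](CO)[C@@H](O)[C@H]3O)c2n1` is the next compound to be measured. It differs from compound 3 in this way: methyl in place of amino on an aromatic carbon. The change sits on an aromatic carbon of a six-membered aromatic ring with two nitrogens, between two ring nitrogen atoms. None of the measured steps gives a readable size, and all three shown values sit at the same limit, so no direction can be drawn from them. The step from compound 3 to compound 4 is therefore expected to be a step that the limit leaves unreadable from compound 3 to compound 4, with the result most likely another limit. Compound 4 is estimated at 30000 nM, with a range from 10000 nM to 100000 nM.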

Compound 4, half-maximal inhibitory concentration: > 20000 nM
Compound 4: a limit, no number (the forecaster's own chance of this, stated with the estimate: 80%); the middle value lies beyond the limit too.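

The changes linking compound 4 to compound 3 and to compound 2 cannot be read as steps, because both compounds in each pair stand at the same limit: the limit of > 20000 nM in this assay, at which 4 of the 4 values shown sit. The compounds shown leave open whether methyl in place of amino, or one of these rings in place of another, changes inhibition at all in this assay.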